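Imidazole to Boc-pyrrolidine on the sulfonamide series

The source may report more compounds than this note shows. Statements on the series, on what has been measured and on what is new or still open speak of the compounds shown alone.

Compound 1 `O=C(CN1CCCC1)N1CCC(NS(=O)(=O)c2cc(S(=O)(=O)c3ccccc3)ccc2C(F)(F)F)CC1` gives 25000 nM
Compound 2 `O=C(Cn1ccnc1)N1CCC(NS(=O)(=O)c2cc(S(=O)(=O)c3ccccc3)ccc2C(F)(F)F)CC1` gives 100000 nM

In a physicochemical assay for solubility (a higher number here means a more soluble compound, a lower number a less soluble compound), compound 2 gives 100000 nM and stands highest of the two measured. For the measured compounds named here, the change from compound 2 to compound 3 `CC(C)(C)OC(=O)N1CCC[C@H]1C(=O)N1CCC(NS(=O)(=O)c2cc(S(=O)(=O)c3ccccc3)ccc2C(F)(F)F)CC1` reads 1-(tert-butoxycarbonyl)pyrrolidin-2-yl in place of (1H-imidazol-1-yl)methyl on a carbonyl carbon and has no direct measured counterpart. Going by the values given here, the one related step is a 4.0-fold higher number from compound 1 to compound 2 (0.60 log units; beyond the scatter) and it is modest, with 1H-imidazol-1-yl entering in place of pyrrolidin-1-yl. Compound 3 also lacks the 1H-imidazol-1-yl, so a lower number is expected, beyond the scatter. The expected size is a 6.7-fold lower number from compound 2 to compound 3 (0.82 log units; beyond the scatter) in this estimate, somewhat larger than the measured step. For compound 3 the estimated value is 15000 nM within an expected range from 3000 nM to 50000 nM as a working figure.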

Compound 3, solubility: 25000 nM
Compound 3: middle estimate off by 1.7-fold (0.22 log units), on the low side; the measured number falls inside the stated range.
By their numbers in this assay, from the lowest: compounds 1 and 3 (each within the scatter of the next); then compound 2.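

In this assay, a 4.0-fold lower number from compound 2 to compound 3 (0.60 log units; beyond the scatter) is a second step away from the (1H-imidazol-1-yl)methyl group on this carbonyl carbon, and it is as large as the first. With no change at the digits printed from compound 1 to compound 3 (within the scatter), the 1-(tert-butoxycarbonyl)pyrrolidin-2-yl and (pyrrolidin-1-yl)methyl groups cannot be told apart here, even though they are built differently. No measurement at hand accounts for these numbers.

Still open, on these data alone, is how a carboxylic acid or a free pyrrolidin-2-yl amine would read at this place. Also open, as far as these compounds go, is whether the 1H-imidazol-1-yl group holds its number on a longer chain.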